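Two Hydroxyls Give Way to One Methoxy

A few compounds are considered here, and "the series" means these few. Any claim that something is new, unique, unknown or untested is made for them only; others in the source may bear on it.

For the measured compounds named here, compound 2 `O=C(N/N=C/c1ccc(O)c(O)c1)c1cccnc1Nc1cccc(C(F)(F)F)c1` is one of two compounds measured in a functional assay on the whole organism (strain Wistar) for inhibition, with Rattus norvegicus as the target, read by paw edema, with a stated time of 2 h, at a dose of 10 mg/kg by the intraperitoneal route (on this read-out lower numbers stand for less inhibition and higher numbers for more inhibition at the one dose given (going by the name of the read-out)), where compound 2 gives 46.9%. Compound 1 `O=C(N/N=C/c1cccc(F)c1)c1cccnc1Nc1cccc(C(F)(F)F)c1` gives 52.8% in this assay, and the step of a number 5.9 percentage points lower from compound 1 to compound 2 (within the scatter) lies within the scatter, so the two stand together. Compound 3 `COc1cccc(/C=N/NC(=O)c2cccnc2Nc2cccc(C(F)(F)F)c2)c1` differs from compound 2 by 3-methoxyphenyl in place of 3,4-dihydroxyphenyl on a carbon with a double bond to nitrogen. Going by the values given here, the only step that bears on this change is the one from compound 1 to compound 2, and it was small, so little movement in this assay is expected. Compound 3 is therefore estimated at 50%, with a range of 38% to 62%. The expected step is a number 3.1 percentage points higher from compound 2 to compound 3 (within the scatter), not beyond the scatter.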

Compound 3, a percentage reported as inhibition, in the whole organism at one dose (the size of the read-out at that dose, not a potency): 49.7%
Beside the measured number, compound 3's estimate is 0.3 percentage points above it; measured number inside the range.
By their numbers in this assay, from the lowest: compounds 2, 3 and 1 (each within the scatter of the next).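

Methoxy in place of fluoro on an aromatic carbon gives a number 3.1 percentage points lower from compound 1 to compound 3 (within the scatter), and 3-methoxyphenyl in place of 3,4-dihydroxyphenyl on a carbon with a double bond to nitrogen gives a number 2.8 percentage points higher from compound 2 to compound 3 (within the scatter). In this assay, this place therefore carries three different substituted phenyl groups with no step beyond the scatter, even though the entering group has 0 hydrogen-bond donors and the leaving group has 2. No available evidence explains this result. On these data alone, whether an amine or a carboxylic acid on the phenyl ring, or a longer chain in place of the methoxy, would also stay within the scatter remains open.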